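Amino in place of methyl on the fused-ring aromatic carbon

The compounds below may be only part of what the source reports. "The series", "measured", "known", "first", "only" and "open" are said of these compounds alone.

Measured so far:
compound 1, `Cc1cc(F)c(CNc2ncc(-c3cccnc3C)c3nncn23)c2c1OCC2`, an ADME assay on cells (Hepatocyte, Rattus norvegicus) for metabolic stability; a lower number here means slower removal, a higher number faster removal of the compound: "not determined" (no result reported)
compound 2, `Cc1ncccc1-c1cnc(NCc2c(F)cc(O)c3c2CCO3)n2cnnc12`, this assay: 50 uL/min

Compound 1 stands without a number in this assay, so no baseline step size can be drawn from it. Compound 3, `Cc1ncccc1-c1cnc(NCc2c(F)cc(N)c3c2CCO3)n2cnnc12`, differs from compound 1 as follows: amino in place of methyl on an aromatic carbon. Within the data shown here, with no measured step to lean on, the change is expected to shift clearance by no more than the usual scatter in either direction. Compound 3 is therefore estimated at 40 uL/min, within 15 uL/min to 110 uL/min, a guess anchored on the value of compound 2 rather than on a measured step.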

Compound 3, intrinsic clearance in a liver preparation (reported as CLH), per the amount of preparation that the assay uses: 7 uL/min
Compound 3: middle estimate off by 5.7-fold (0.76 log units), on the high side; measured number below the stated range.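

In this assay, among these compounds, amino in place of hydroxy on this aromatic carbon gives a 7.1-fold lower number from compound 2 to compound 3 (0.85 log units; beyond the scatter) and so provides the first readable step at this position. The read-out at this carbon therefore depends on which of these two groups it carries. No measurement at hand accounts for the step. Compound 1 gives no single number, so the change from methyl to amino cannot be read. On these data alone, whether a methoxy or a dimethylamino group on this carbon would give a number nearer compound 2 or compound 3 remains open.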